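Amide-cap variants in a cytotoxicity series

The source may hold more compounds than are shown below. What is called first, only, known or untested is meant among the compounds shown, and "the series" means these compounds.

Compound 1 `CCCCCCCCCCCCCCCCCCNC(=O)[C@@H](NC(=O)c1ccccc1)[C@@H](C)O` in a functional assay on HepG2 cells (Homo sapiens) for cytotoxicity, read by MTT assay, with a stated time of 48 h (a higher number here means a weaker inhibitor, a lower number a stronger inhibitor), gives > 400000 nM, which is a limit of the assay. Compound 2 `CCCCCCCCCCCCCCCCCCNC(=O)[C@@H](NC(=O)c1cccs1)[C@@H](C)O` gives 92000 nM. Compound 3 `CCCCCCCCCCCCCCCCCCNC(=O)[C@@H](NC(=O)c1cc2ccccc2n1C)[C@@H](C)O` gives > 200000 nM, again a limit.

Going by the values given here, compound 3 thus stands only at a limit, as the limit of > 200000 nM in this assay, at which 1 of the 3 values shown sits, records; compound 2 is the one value that is a number. Compound 4 `C/C=C/C=C/C(=O)N[C@H](C(=O)NCCCCCCCCCCCCCCCCCC)[C@@H](C)O` differs from compound 3 by penta-1,3-dien-1-yl in place of 1-methyl-1H-indol-2-yl on a carbonyl carbon. The measured steps of an at least 4.3-fold lower number from compound 1 to compound 2 (0.63 log units; beyond the scatter) and an at least 2.1-fold higher number from compound 2 to compound 3 (0.33 log units; beyond the scatter) show that exchanging the group on the carbonyl carbon can shift this assay by modest amounts, while a step that the two limits leave unreadable from compound 1 to compound 3 stays unreadable. Among the compounds with values here, no measured step involves an open-chain group, so the direction is uncertain; a modest change is expected, an at least 1.3-fold lower number from compound 3 to compound 4 (0.12 log units; that floor lies within the scatter). Compound 4 is estimated at 150000 nM, within 50000 nM to 400000 nM.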

Compound 4, half-maximal inhibitory concentration: 284000 nM
For compound 4 the middle estimate is 1.9-fold (0.28 log units) below the measured one; measured number inside the range.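

An open-chain group on this carbonyl carbon gives a second true number in this assay, with a 3.1-fold higher number from compound 2 to compound 4 (0.49 log units; beyond the scatter) when penta-1,3-dien-1-yl replaces thiophen-2-yl. Against phenyl the record reads an at least 1.4-fold lower number from compound 1 to compound 4 (0.14 log units; that floor lies within the scatter), so no order can be claimed there. The step involving the 1-methyl-1H-indol-2-yl group cannot be read, because compound 3 stands at a limit: the limit of > 200000 nM in this assay, at which 1 of the 4 values shown sits.

Open, on these data alone, is whether the two double bonds of penta-1,3-dien-1-yl matter, which a saturated pentyl chain in the same place would test. Also open, as far as these compounds go, is how an amine on that chain would read in this assay.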